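This account rests on a few compounds, and the source may have more. Where it says the series, first, only, none or still open, it means among the compounds named here.

Measured so far in a functional assay on NUGC-3 cells (Homo sapiens) for antiproliferative activity, read by sulforhodamine B assay; a higher number here means a weaker inhibitor of growth, a lower number a stronger inhibitor of growth:
- compound 1 `CC(C)CCCOc1cccc(O)c1C(=O)/C=C/c1ccc(O)cc1`: 3520 nM
- compound 2 `O=C(/C=C/c1ccc(O)cc1)c1c(O)cccc1OCC1CCCCC1`: > 30000 nM, a limit of the assay and not a number
- compound 3 `CC(C)COc1cccc(O)c1C(=O)/C=C/c1ccc(O)cc1`: 2980 nM

Among the compounds with values here, compound 3 stands level with compound 1, a 1.2-fold lower number from compound 1 to compound 3 (0.07 log units; within the scatter), and these are the only two numbers in this assay.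

Next is compound 4 `O=C(/C=C/c1ccc(O)cc1)c1c(O)cccc1OCCC1CCCC1`. The change is cyclopentylmethyl in place of isopropyl on a saturated chain carbon bound to an oxygen on an aromatic ring.

Two kinds of measured step bear on this. Swapping one open-chain group for another made no difference beyond the scatter, a 1.2-fold lower number from compound 1 to compound 3 (0.07 log units; within the scatter). Within the data shown here, the only measured compound with a ring in this group, compound 2, stands well apart from both others, an at least 8.5-fold higher number from compound 1 to compound 2 (0.93 log units; beyond the scatter) and an at least 10-fold lower number from compound 2 to compound 3 (1.00 log units; beyond the scatter). Compound 4 also carries a ring, though a five-membered one on a different chain, so that single precedent is only a partial guide.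

The expected step is a 2.3-fold higher number from compound 3 to compound 4 (0.37 log units; beyond the scatter), a move to a higher number and probably a smaller one than the ring step seen so far. The estimated value for compound 4 is 7000 nM, with an expected range of 2000 nM to 30000 nM.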

Compound 4, concentration for 50% growth inhibition: 3200 nM
The estimate for compound 4 lay 2.2-fold (0.34 log units) above the measured number; low and high end bracket the measured number.
By their numbers in this assay, from the lowest: compounds 3, 4 and 1 (each within the scatter of the next). At a limit, above all of these: compound 2.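

In this assay, a ring in this group does not by itself move the number: the change from isopropyl to cyclopentylmethyl gives a 1.1-fold higher number from compound 3 to compound 4 (0.03 log units; within the scatter), and the open-chain comparison gives a 1.1-fold lower number from compound 1 to compound 4 (0.04 log units; within the scatter), so three groups of differing shape now read level. The large gap seen for the cyclohexyl compound is therefore not shared by every ring-bearing group, with the step between the two ring groups being an at least 9.3-fold lower number from compound 2 to compound 4 (0.97 log units; beyond the scatter). Compound 2 remains a limit of the assay and not a number: the limit of > 30000 nM in this assay, at which 1 of the 4 values shown sits.

Compound 2 and compound 4 differ in both ring size and the length of chain leading to the ring, and the compounds shown do not separate these two features. As far as these compounds go, how an amine, a carboxylic acid or a much longer chain would read at this place also remains open.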